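Swapping an amino for a methyl on the diaminopyrimidine

The source may hold more compounds than are shown below. What is called first, only, known or untested is meant among the compounds shown, and "the series" means these compounds.

Three compounds share a core and differ only in one group on a pendant aromatic ring. Compound 1 `C[C@H](Nc1nc(N)nc(N)c1C#N)c1c(-c2ccccc2)c(=O)n2cc(F)ccc2c1-c1ccc(C(N)=O)cc1` carries a carbamoyl there and in an ADME assay on microsomes from liver (Rattus norvegicus), read by LC-MS, using NADPH, with a stated time of 30 min, tested at 1 uM (on this read-out higher numbers stand for a more stable compound and lower numbers for a less stable compound), compound 1 gives 100%. Compound 2 `COc1ccc(-c2c([C@H](C)Nc3nc(N)nc(N)c3C#N)c(-c3ccccc3)c(=O)n3cc(F)ccc23)cc1` carries a methoxy and in this assay compound 2 gives 76%. Compound 3 `C[C@H](Nc1nc(N)nc(N)c1C#N)c1c(-c2ccccc2)c(=O)n2cc(F)ccc2c1-c1ccc(F)cc1` carries a fluoro and in this assay compound 3 gives 77%. Among these numbers compound 3 stands second highest: its value and that of compound 2 lie within the scatter of each other, while a number 23 percentage points lower from compound 1 to compound 3 (beyond the scatter) and a number 24 percentage points lower from compound 1 to compound 2 (beyond the scatter) are both beyond it.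

Compound 4 `Cc1nc(N)nc(N[C@@H](C)c2c(-c3ccccc3)c(=O)n3cc(F)ccc3c2-c2ccc(F)cc2)c1C#N` keeps the fluoro and instead alters the other end of the molecule: methyl in place of amino on an aromatic carbon, that is, on an aromatic carbon of a six-membered aromatic ring with two nitrogens, next to the ring nitrogen and ortho to a cyano group. Among the measured compounds shown here, none of the measured steps touches this ring; all three concern the pendant aromatic ring, so no measured step bears directly on the new change. With nothing to argue otherwise, the expectation is a step from compound 3 to compound 4 of about a number 7 percentage points lower from compound 3 to compound 4 (within the scatter), within or only just beyond the scatter. Compound 4 is therefore estimated at 70%, in a range from 45% to 92%.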

Compound 4, percent of the compound remaining in the Rattus norvegicus assay: 85%
The estimate for compound 4 lay 15 percentage points below the measured number, and the stated range covers the measured number.
By their numbers in the Rattus norvegicus assay, from the lowest: compounds 2, 3 and 4 (each within the scatter of the next); then compound 1.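

Among the compounds shown here, this is the first look at the 2,6-diamino-5-cyanopyrimidin-4-yl end of the molecule, since every earlier step changed the pendant aromatic ring. In the Rattus norvegicus assay, methyl in place of amino gives a number 8 percentage points higher from compound 3 to compound 4 (within the scatter), so this pair shows that the amino group, with its hydrogen-bond donor and acceptor, can be exchanged at this position without a readable change in the percentage of compound remaining. In a physicochemical assay for lipophilicity, at pH 7.4 (a higher number here means a more lipophilic compound, a lower number a more polar compound), the same swap does register, from compound 3 (2.38) to compound 4 (3.26), and a compound that is clearly more lipophilic here stays level in the microsomal read-out, which means that at this position a rise in lipophilicity comes without a readable cost in stability: the measured distribution coefficient of compound 3, 2.38, and of compound 4, 3.26, a number 0.88 log units higher (beyond the scatter).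

On these data alone, this rests on one matched pair carrying the fluoro group, so it remains open whether the same swap would behave alike with the carbamoyl of compound 1 on the pendant ring. As far as these compounds go, it is equally open whether a larger or different group in the same place, such as an ethyl, a chlorine or a hydroxyl, would leave the stability as undisturbed as the methyl of compound 4 does.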